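Swapping the distal ring of a trimethoxyphenyl pyrazolopyrimidine

This account rests on a few compounds, and the source may have more. Where it says the series, first, only, none or still open, it means among the compounds named here.

Three compounds share one core and differ only in the group attached to it. Compound 1 `COc1cc(-c2ccnc3cc(-c4ccc(C)cc4)nn23)cc(OC)c1OC` carries a 4-methylphenyl; in a functional assay on B16-F0 cells (Mus musculus) for inhibition, read by CCK-8 assay, with a stated time of 48 h (on this read-out lower numbers stand for stronger inhibition and higher numbers for weaker inhibition), compound 1 gives 21 nM. Compound 2 `COc1cc(-c2ccnc3cc(-c4ccc(Cl)cc4)nn23)cc(OC)c1OC` carries chlorine in place of that methyl, and compound 2 gives 4090 nM. Compound 3 `COc1ccc(-c2cc3nccc(-c4cc(OC)c(OC)c(OC)c4)n3n2)cc1` carries methoxy there, and compound 3 gives 1410 nM. Compound 3 thus stands second highest of the three numbers, beyond the scatter from both neighbours.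

Compound 4 `COc1cc(-c2ccnc3cc(-c4ccc5c(ccn5C)c4)nn23)cc(OC)c1OC` changes more than a single substituent: 1-methyl-1H-indol-5-yl in place of 4-methoxyphenyl on an aromatic carbon. Among the measured compounds shown here, no measured step covers such a ring swap. The nearest guides are a 190-fold higher number from compound 1 to compound 2 (2.29 log units; beyond the scatter), a 67-fold higher number from compound 1 to compound 3 (1.83 log units; beyond the scatter) and a 2.9-fold lower number from compound 2 to compound 3 (0.46 log units; beyond the scatter); they show that even a small change on this aromatic carbon can move the number far, in either direction. A large step is therefore plausible, but its direction cannot be read from these data. Compound 4 is estimated at 800 nM, within 60 nM to 8000 nM, meaning an expected 1.8-fold lower number from compound 3 to compound 4 (0.25 log units; within the scatter).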

Compound 4, half-maximal inhibitory concentration: 48 nM
For compound 4 the middle estimate is 17-fold (1.22 log units) above the measured one; the measured number lies below the stated range.
By their numbers in this assay, from the lowest: compound 1; then compound 4; then compound 3; then compound 2.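

In this assay a group with two rings works at this aromatic carbon of the shared core: 1-methyl-1H-indol-5-yl gives a 29-fold lower number from compound 3 to compound 4 (1.47 log units; beyond the scatter) and an 85-fold lower number from compound 2 to compound 4 (1.93 log units; beyond the scatter). A low number is therefore not confined to the 4-methylphenyl of compound 1, although the new group does not fully match it, with a 2.3-fold higher number from compound 1 to compound 4 (0.36 log units; beyond the scatter) as a modest step that still lies beyond the scatter. Among these four compounds, then, 4-methylphenyl and 1-methyl-1H-indol-5-yl go with low numbers and 4-methoxyphenyl and 4-chlorophenyl with high numbers, and nothing available explains that split.

As far as these compounds go, it stays open whether the methyl on 1-methyl-1H-indol-5-yl matters or the second ring alone suffices. Also open, from the compounds shown here alone, is how a longer chain such as ethyl, or an amine such as dimethylamino, would fare in place of the methyl of compound 1.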